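Aminopropylamino Chain Replaces Nitrophenyl on the Ring Oxygen

This account rests on a few compounds, and the source may have more. Where it says the series, first, only, none or still open, it means among the compounds named here.

For the measured compounds named here, compound 2 `COc1cc(Nc2ncc(Br)c(Oc3ccc([N+](=O)[O-])cc3F)n2)cc(OC)c1OC` is the only compound with a numerical reading in a functional assay on MCF7 cells (Homo sapiens) for antiproliferative activity, read by MTT assay, with a stated time of 24 h; on this read-out lower numbers stand for stronger inhibition and higher numbers for weaker inhibition: in this assay compound 2 gives 19600 nM. Compound 1 `CNC(=O)c1ccccc1Oc1nc(Nc2ccc(Cl)cc2F)ncc1Br` sits at a limit of this assay; in this assay compound 1 gives > 50000 nM, which is a limit rather than a number. Of the two values shown, (the limit of > 50000 nM in this assay, at which 1 of the 2 values shown sits). Compound 3 `COc1cc(Nc2ncc(Br)c(ONCCCN)n2)cc(OC)c1OC` has not yet been measured in this assay. It differs from compound 2 in a single place: (3-aminopropyl)amino in place of 2-fluoro-4-nitrophenyl on an oxygen on an aromatic ring. No step between two measured compounds is available here, so the direction of this change has no precedent among the compounds shown. The departing 2-fluoro-4-nitrophenyl carries one six-membered aromatic ring of carbon only, while the entering (3-aminopropyl)amino brings a chain with no ring and two hydrogen-bond donors. The expected step is a 1.8-fold higher number from compound 2 to compound 3 (0.25 log units; within the scatter), toward weaker inhibition and beyond the usual scatter, though the two measured compounds give little footing for a firm number. In this assay compound 3 is expected to give 35000 nM, with a likely range from 8000 nM to 150000 nM.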

Compound 3, half-maximal inhibitory concentration: 21900 nM
Compound 3: middle estimate off by 1.6-fold (0.20 log units), on the high side, within the range that was stated.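

In this assay, putting (3-aminopropyl)amino in place of 2-fluoro-4-nitrophenyl gives a 1.1-fold higher number from compound 2 to compound 3 (0.05 log units; within the scatter), so the two readings cannot be told apart. This is the first step shown at this place, on an oxygen on an aromatic ring, and it shows that a six-membered aromatic ring of carbon only and a chain with no ring and two hydrogen-bond donors can stand there with readings that lie within the scatter of each other. Nothing measured among the compounds shown accounts for this outcome.

On these data alone, a single step cannot tell whether this place is insensitive to what it carries or whether these two groups merely happen to give matching readings, so it remains open whether a longer chain, a shorter chain or a carboxylic acid in place of the terminal amine would move the number beyond the scatter. As far as these compounds go, it also remains open whether a dimethylamine at the end of the chain, or a saturated ring such as piperidine in place of the chain, would give a stronger reading on this shared core.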